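Selenomethyl to Amino on a Fused Bicyclic Core

This account rests on a few compounds, and the source may have more. Where it says the series, first, only, none or still open, it means among the compounds named here.

Compound 1 `COc1ccc(CNc2nc([Se]C)nc3ccccc23)cc1` gives, in an ADME assay on BEAS-2B cells (Homo sapiens) for cytotoxicity, read by MTT assay, with a stated time of 72 h (a lower number here means a stronger inhibitor of growth, a higher number a weaker inhibitor of growth), a value of > 100000 nM, which is a limit of the assay and not a number. Compound 2 `C[Se]c1nc([Se]C)c2cccnc2n1` carries two selenomethyl groups on its bicyclic core, and for compound 2 the result in this assay is "not determined" (no result reported). So compound 2 stands on no single number: the one value shown for this assay is the limit of > 100000 nM in this assay, at which 1 of the 2 values shown sits, and compound 2 itself contributes none.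

Compound 3 `C[Se]c1nc(N)c2cccnc2n1` differs from compound 2 in one place, one nitrogen atom in place of a group of 2 heavy atoms (1 carbon, 1 selenium; no ring), on an aromatic carbon. Going by the values given here, no step between measured compounds exists that would tell how large such a change is in this assay, and compound 2 has no value to step from. With only the limit of compound 1 as a reference, no step beyond the usual scatter is expected in this assay in either direction, and the result for compound 3 may itself come back as a limit. Compound 3 is therefore expected to give about 80000 nM in this assay, within a range of 20000 nM to 200000 nM.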

Compound 3, concentration for total growth inhibition: 90800 nM
Compound 3: middle estimate off by 1.1-fold (0.05 log units), on the low side, within the range that was stated.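

In this assay, going by these compounds alone, compound 2 has no result reported, so no step from compound 2 to compound 3 can be read, and the value of compound 3 stands without a partner. The compounds shown leave open how large an effect on growth inhibition the change to amino on the shared core has in this assay.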